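This account rests on a few compounds, and the source may have more. Where it says the series, first, only, none or still open, it means among the compounds named here.

Compound 3 `CC1CCN(c2c(S(=O)(=O)c3ccccc3)cnc3c(F)cccc23)CC1` stands second highest of the three measured compounds in an assay on isolated protein for displacement of a labelled ligand from metabotropic glutamate receptor 5 (Homo sapiens), with a stated time of 60 min, tested at 1 uM (a lower number here means less inhibition, a higher number more inhibition at the concentration tested (going by the name of the read-out)), where compound 3 gives 13%. Its nearest neighbour is compound 2 `CC1CCN(c2c(S(=O)(=O)c3cc(F)cc(F)c3)cnc3c(F)cccc23)CC1`, which gives 9%, separated by a number 4 percentage points higher from compound 2 to compound 3 (within the scatter). The furthest is compound 1 `Cc1ccc(S(=O)(=O)c2cnc3c(F)cccc3c2N2CCC(C)CC2)cc1`, which gives 93%, separated by a number 80 percentage points lower from compound 1 to compound 3 (beyond the scatter).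

Compound 4 `Cc1ccc(S(=O)(=O)c2cnc3c(F)cccc3c2N2CCC(C)CC2)cc1F` differs from compound 3 by 3-fluoro-4-methylphenyl in place of phenyl on a sulfonyl sulfur. For the measured compounds named here, two measured steps bear on this change. The step of a number 80 percentage points lower from compound 1 to compound 3 (beyond the scatter) shows that taking the methyl away from the 4-methylphenyl is a large loss, and compound 4 restores that methyl. The step of a number 84 percentage points lower from compound 1 to compound 2 (beyond the scatter) shows that a fluorinated phenyl lacking the methyl is also a large loss, while a number 4 percentage points higher from compound 2 to compound 3 (within the scatter) shows that fluorine on the phenyl without the methyl changes nothing beyond the scatter. The methyl therefore appears to carry the large difference among these three compounds, and the added fluorine in compound 4 has no counterpart step that is beyond the scatter.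

A large increase in this assay is therefore expected for compound 4, roughly a number 65 percentage points higher from compound 3 to compound 4 (beyond the scatter), because a number 80 percentage points lower from compound 1 to compound 3 (beyond the scatter) was large and is here reversed. Compound 4 is estimated at 78%, with a range from 45% to 97%.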

Compound 4, a percentage reported as inhibition, at one concentration (the size of the read-out at that concentration, not a potency): 93%
Compound 4: the middle estimate sits 15 percentage points below what was measured; the range from low to high includes it.
By their numbers in this assay, from the lowest: compounds 2 and 3 (each within the scatter of the next); then compounds 1 and 4 (each within the scatter of the next).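

For the compounds shown here, the fluoro in place of hydrogen on an aromatic carbon of the group on the sulfonyl sulfur gives no change at the digits printed from compound 1 to compound 4 (within the scatter) in this assay, so a ring carrying the methyl keeps its high read-out with a fluorine added, whereas the earlier compounds showed fluorine only on a ring without the methyl. The large steps of a number 80 percentage points higher from compound 3 to compound 4 (beyond the scatter) and a number 84 percentage points higher from compound 2 to compound 4 (beyond the scatter) show that 3-fluoro-4-methylphenyl on this sulfonyl sulfur stands apart from both phenyl and 3,5-difluorophenyl, and the two compounds with a methyl on this ring now form a high group clearly separated from the two without one. The compounds shown offer no measurement that explains this separation.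

As far as these compounds go, this read-out, taken at one concentration, is not a potency, so it remains open whether compound 1 and compound 4 would differ at a lower concentration. Going by these compounds alone, it is also open whether the methyl is the only group that serves at this place, or whether an ethyl, a methoxy or a chlorine on the same ring would give a similar number.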